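The compounds below may be only part of what the source reports. "The series", "measured", "known", "first", "only" and "open" are said of these compounds alone.

For the measured compounds named here, compound 1 `COc1ccc(C2=NN(C3=NC(=O)/C(=C4\C(=O)Nc5ccccc54)S3)C(c3ccc(OC)cc3)C2)cc1` sits at the top of the two numbers so far: in a functional assay on cells (Cancer cell lines, Homo sapiens) for cytotoxicity, read by sulforhodamine B assay, with a stated time of 48 h (on this read-out higher numbers stand for weaker inhibition of growth and lower numbers for stronger inhibition of growth), compound 1 gives 100000 nM. Going by the values given here, its only measured neighbour is compound 2 `COc1ccc(C2CC(c3ccc4ccccc4c3)=NN2C2=NC(=O)/C(=C3\C(=O)Nc4ccccc43)S2)cc1`, which in this assay gives 12400 nM; the one recorded step, an 8.1-fold lower number from compound 1 to compound 2 (0.91 log units; beyond the scatter), comes from naphthalen-2-yl in place of 4-methoxyphenyl on a carbon with a double bond to nitrogen.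

Compound 3 `COc1ccc(C2=NN(C3=NC(=O)/C(=C4\C(=O)Nc5ccccc54)S3)C(c3ccc(Cl)cc3)C2)cc1` changes compound 1 elsewhere: chloro in place of methoxy on an aromatic carbon. The naphthyl step between compound 1 and compound 2 touches a different part of the shared core and so does not bear on this change. Among the compounds with values here, no measured step here speaks to exchanging methoxy for chloro at this place, so the expectation rests on the starting number of compound 1 alone. The change is expected to give a step of a 1.4-fold lower number from compound 1 to compound 3 (0.15 log units; within the scatter) in this assay, which is within the scatter, with a slight lean toward a lower number. Compound 3 is therefore estimated at 70000 nM in this assay, with a range from 25000 nM to 150000 nM.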

Compound 3, concentration for total growth inhibition: 100000 nM
The estimate for compound 3 lay 1.4-fold (0.15 log units) below the measured number; the range from low to high includes it.
By their numbers in this assay, from the lowest: compound 2; then compounds 1 and 3 (each within the scatter of the next).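

In this assay, chloro in place of methoxy gives no change at the digits printed from compound 1 to compound 3 (within the scatter). For the compounds shown here, this is the first reading at this place on the shared core, and it shows that going from 4-methoxyphenyl to 4-chlorophenyl, with one heavy atom entering for two and one hydrogen-bond acceptor leaving, does not move the number beyond the scatter. The earlier step, an 8.1-fold lower number from compound 1 to compound 2 (0.91 log units; beyond the scatter), belongs to a different place, on a carbon with a double bond to nitrogen, so among these compounds only that place has given a change beyond the scatter, and nothing given here explains the absence of a change at the place para to a large group.

Only methoxy and chloro are shown at this place, which leaves open whether an amine or a carboxylic acid on the same ring would shift the number in this assay. On these data alone, it is also open whether chloro in place of methoxy would read the same on the core of compound 2, which carries naphthalen-2-yl and gives a lower number than compound 1.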